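Piperazin-1-yl in place of (pyridin-3-yl)amino on the shared core

The source may report more compounds than this note shows. Statements on the series, on what has been measured and on what is new or still open speak of the compounds shown alone.

Going by the values given here, compound 2 `Cn1ccc2cc(-c3ccc4oc(Nc5cccnc5)nc4c3)ccc21` gives 226 nM in an assay on HEK293 cells for inhibition of Fatty-acid amide hydrolase 1 (Homo sapiens), read by fluorescence (on this read-out lower numbers stand for stronger inhibition and higher numbers for weaker inhibition), the lower of the two numbers measured so far; compound 1 `Cn1ccc2cc(-c3ccc4oc(Cc5ccccc5)nc4c3)ccc21` gives 488 nM in this assay, and the step of a 2.2-fold lower number from compound 1 to compound 2 (0.33 log units; beyond the scatter) separates them. Compound 3 `Cn1ccc2cc(-c3ccc4oc(N5CCNCC5)nc4c3)ccc21` keeps the shared core of compound 2 and carries the change (piperazin-1-yl in place of (pyridin-3-yl)amino on an aromatic carbon). Among the compounds with values here, no measured step bears directly on this exchange: the only step available, a 2.2-fold lower number from compound 1 to compound 2 (0.33 log units; beyond the scatter), swapped a benzyl for a (pyridin-3-yl)amino group, and it was modest. The two measured compounds give no firm direction for a change from an aromatic amine to a non-aromatic ring at this position. Compound 3 is therefore expected to sit close to compound 2, with a step of a 1.8-fold higher number from compound 2 to compound 3 (0.25 log units; within the scatter) in this assay, not beyond the scatter. The estimated value for compound 3 is 400 nM, within a range from 150 nM to 1100 nM.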

Compound 3, half-maximal inhibitory concentration: > 1000 nM
Compound 3: no number, only a limit; the forecaster's own chance of this, stated with the estimate: 5%; at least 2.5-fold (0.39 log units) between middle value and limit.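

In this assay compound 3 reads only as a limit: the limit of > 1000 nM in this assay, at which 1 of the 3 values shown sits. On this aromatic carbon, next to the ring nitrogen and next to the ring oxygen, piperazin-1-yl in place of (pyridin-3-yl)amino gives an at least 4.4-fold higher number from compound 2 to compound 3 (0.64 log units; beyond the scatter), and piperazin-1-yl in place of benzyl gives an at least 2.0-fold higher number from compound 1 to compound 3 (0.31 log units; beyond the scatter). The position therefore separates these groups more clearly than the earlier pair could, since both groups in that pair carry an aromatic ring, and among the three compounds the one with the non-aromatic ring is the weakest inhibitor.

From the compounds shown here alone, how far compound 3 lies past its limit stays unknown, so both steps give only a lower bound on the size of the change. Three groups also cannot show whether the aromatic ring itself matters, which a phenylamino group or a morpholin-4-yl ring at this position would help to test.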